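Swapping Nitrile for Methoxy in a Cytotoxicity Series

This account rests on a few compounds, and the source may have more. Where it says the series, first, only, none or still open, it means among the compounds named here.

Compound 1 `CCc1ccc(-c2nc3c(c(C)nn3-c3ccccc3)c(-c3ccccc3C#N)c2C#N)cc1` was examined in an ADME assay on BJ cells (Homo sapiens) for cytotoxicity, with a stated time of 72 h; on this read-out lower numbers stand for an effect already at smaller amounts and higher numbers for an effect only at larger amounts of compound. In this assay compound 1 reaches only a limit of the assay, > 20000 nM. Compound 2 `CCc1ccc(-c2nc3c(c(C)nn3-c3ccccc3)c(-c3ccccc3Br)c2C#N)cc1` carries bromo in place of cyano on an aromatic carbon; in this assay compound 2 likewise returns a limit, > 20000 nM. Compound 3 `CCc1ccc(-c2nc3c(c(C)nn3-c3ccccc3)c(-c3ccccc3F)c2C#N)cc1` carries fluoro in place of cyano on an aromatic carbon; in this assay compound 3 again gives a limit, > 20000 nM. The steps a step that the two limits leave unreadable from compound 1 to compound 2, a step that the two limits leave unreadable from compound 1 to compound 3 and a step that the two limits leave unreadable from compound 2 to compound 3 cannot be sized because of the limit of > 20000 nM in this assay, at which 3 of the 3 values shown sit. Compound 4 `CCc1ccc(-c2nc3c(c(C)nn3-c3ccccc3)c(-c3ccccc3OC)c2C#N)cc1` differs from compound 1 by methoxy in place of cyano on an aromatic carbon. For the measured compounds named here, with no measured step readable, the expected step that the limit leaves unreadable from compound 1 to compound 4 is a step of no readable size, most likely ending at the limit again. Compound 4 is estimated at 30000 nM, between 15000 nM and 80000 nM.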

Compound 4, half-maximal effective concentration: > 20000 nM
Compound 4: no number, only a limit; the forecaster's own chance of this, stated with the estimate: 80%; the middle value is on the limit's open side.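

The steps to compound 4 from compound 1, compound 2 and compound 3 cannot be read, because each of these compounds gives only a limit: the limit of > 20000 nM in this assay, at which 4 of the 4 values shown sit. As far as these compounds go, whether any of these aromatic substitutions changes cytotoxicity in this assay stays open.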